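This account rests on a few compounds, and the source may have more. Where it says the series, first, only, none or still open, it means among the compounds named here.

Compound 1 `CSc1ccc(F)cc1NCC1=NCCN1`: 6.17 nM
Compound 2 `CS(=O)(=O)c1ccc(F)cc1NCC1=NCCN1`: 2630 nM

For the measured compounds named here, in an assay for binding affinity to Alpha-1D adrenergic receptor (Homo sapiens), read by radioligand binding (a higher number here means a weaker inhibitor, a lower number a stronger inhibitor), compound 1 holds the lowest of the two numbers; the only other measured number is a 430-fold higher number from compound 1 to compound 2 (2.63 log units; beyond the scatter). Compound 3 `CSc1ccc(C(F)(F)F)cc1NCC1=NCCN1` is not yet measured and differs from compound 1 by trifluoromethyl in place of fluoro on an aromatic carbon. Going by the values given here, the single measured step swaps methylsulfonyl for methylsulfanyl, a different group from the fluoro changed here, so no measured step bears on the change to compound 3. With no guide in the data, the step is expected to stay within the scatter, a 1.5-fold higher number from compound 1 to compound 3 (0.16 log units; within the scatter). Compound 3 is therefore estimated at 9 nM, with a range from 2.5 nM to 40 nM.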

Compound 3, inhibition constant: 479 nM
Compound 3: the middle estimate sits 53-fold (1.73 log units) below what was measured, and the stated range ends below it.
By their numbers in this assay, from the lowest: compound 1; then compound 3; then compound 2.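

The ring carbon para to a methylsulfanyl group is not a free place to make changes: in this assay, trifluoromethyl in place of fluoro gives a 78-fold higher number from compound 1 to compound 3 (1.89 log units; beyond the scatter). So a large loss is not confined to changes at the sulfur, and a swap on this other ring carbon also moves the number well beyond the scatter. Nothing measured here explains the size of this step. Still open, from the compounds shown here alone, is how chloro, methyl or methoxy would read at this same carbon, and so whether fluoro stands out or trifluoromethyl alone raises the number.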